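The source may report more compounds than this note shows. Statements on the series, on what has been measured and on what is new or still open speak of the compounds shown alone.

Compound 1 `C=C(CC(=O)Nc1cc(C(F)(F)F)ccc1F)C(=O)O`: in an ADME assay on MDCK cells (Canis lupus familiaris) for cytotoxicity, read by MTT assay, with a stated time of 72 h (on this read-out higher numbers stand for lower toxicity in this test and lower numbers for higher toxicity in this test), compound 1 gives > 110000 nM, which is a limit of the assay rather than a number.
Compound 2 `C=C(CC(=O)Nc1ccc(F)cc1C(F)(F)F)C(=O)O`: compound 2 gives > 110000 nM, again a limit of the assay.
Compound 3 `C=C(CC(=O)Nc1ccccc1C(F)(F)F)C(=O)O`: compound 3 gives > 110000 nM, also a limit of the assay.

The change from compound 2 to compound 3 is hydrogen in place of fluoro on an aromatic carbon. It gives a step that the two limits leave unreadable from compound 2 to compound 3, since both values sit at the limit of > 110000 nM in this assay, at which 3 of the 3 values shown sit. How the core of compound 1 differs from that of compound 2 is not broken down here.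

Compound 4 `C=C(CC(=O)Nc1cccc(C(F)(F)F)c1)C(=O)O` differs from compound 1 by hydrogen in place of fluoro on an aromatic carbon. This is the same kind of change, not the same: in the measured pair the site is meta to a trifluoromethyl group and para to a group of 9 heavy atoms, whereas here it is ortho to a group of 9 heavy atoms and para to a trifluoromethyl group. In this assay compound 1 gave > 110000 nM, a limit of the assay. Compound 4 is therefore expected to show a step that the limit leaves unreadable from compound 1 to compound 4, with the value again likely to be reported only as a limit. The estimate for compound 4 is 150000 nM, ranging from 80000 nM to 400000 nM.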

Compound 4, half-maximal cytotoxic concentration: > 110000 nM
Compound 4 ended at the assay's limit; the forecaster's own chance of this, stated with the estimate: 85%; the middle value does not contradict the limit.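

No new step can be read between compound 1 and compound 4, because both stand only at a limit in this assay and neither gives a number: the limit of > 110000 nM in this assay, at which 4 of the 4 values shown sit.
The compounds shown leave open how far each lies from that limit, and so whether the hydrogen or fluoro on the aromatic carbon changes the read-out at all.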